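Cyclopentyl to Oxan-4-yl: Expected Stability in Liver Microsomes

The source may report more compounds than this note shows. Statements on the series, on what has been measured and on what is new or still open speak of the compounds shown alone.

Measured compounds:
compound 1 `C1CCC(C(CC2CCCCN2)C2CCC2)CC1`: > 3.33 h
compound 2 `C1CCC(C(CC2CCCCN2)C2CCCC2)CC1`: > 2.5 h

In an ADME assay on microsomes from liver (Homo sapiens) for metabolic stability, read by LC-MS, using NADPH, with a stated time of 45 min, tested at 3 uM (a lower number here means that the compound disappears faster, a higher number that the compound lasts longer), compound 2 gives > 2.5 h, which is a limit of the assay and not a number. Compound 1 likewise sits at a limit in this assay. The step that the two limits leave unreadable from compound 1 to compound 2 therefore has no readable size. Compound 3 `C1CCC(C(CC2CCCCN2)C2CCOCC2)CC1` carries oxan-4-yl in place of cyclopentyl on a saturated chain carbon bound to a saturated chain carbon and a saturated ring carbon. Among the measured compounds shown here, no measured step speaks to this change, so no shift beyond the usual scatter is expected in this assay. Compound 3 is expected to give about 3 h, in the range 1.5 h to 6 h. The expected step that the limit leaves unreadable from compound 2 to compound 3 is small, and the assay may again report only a limit.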

Compound 3, half-life: 1.4 h
Beside the measured number, compound 3's estimate is 2.1-fold (0.33 log units) above it; measured number below the stated range.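

In this assay, among the compounds shown here, oxan-4-yl is the first group at this position to give a readable half-life rather than a limit. Replacing cyclopentyl gives an at least 1.7-fold lower number from compound 2 to compound 3 (0.25 log units; that floor lies within the scatter), and replacing cyclobutyl gives an at least 2.3-fold lower number from compound 1 to compound 3 (0.37 log units; beyond the scatter). The full size of the cyclopentyl step cannot be read, because compound 2 stands at a limit: the limit of > 2.5 h in this assay, at which 1 of the 3 values shown sits.

Still open, as far as these compounds go, is whether the ring oxygen or the ring size accounts for the lower number, a question that a cyclohexyl group at this place could settle. From the compounds shown here alone, how a ring amine such as piperidin-4-yl would fare also remains unknown.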